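Ester-bearing aminopyrimidines against a breast cancer cell line

A few compounds are considered here, and "the series" means these few. Any claim that something is new, unique, unknown or untested is made for them only; others in the source may bear on it.

Compound 1 `COC(=O)CN(C)c1nc(Nc2ccc(Cl)cc2)ncc1[N+](=O)[O-]`: 21200 nM
Compound 2 `COC(=O)CN(C)c1nc(Nc2cccc(OC)c2)ncc1[N+](=O)[O-]`: 58000 nM
Compound 3 `CCOC(=O)CN(Cc1ccccc1)c1nc(Nc2ccc(Cl)cc2)ncc1[N+](=O)[O-]`: 34400 nM

Of the compounds shown here, three have been measured in a functional assay on MDA-MB-231 cells (Homo sapiens) for antiproliferative activity, read by MTT assay, with a stated time of 48 h; a lower number here means a stronger inhibitor, a higher number a weaker inhibitor. Compound 1 gives 21200 nM, and compound 2 gives 58000 nM. The two differ in one place, (3-methoxyphenyl in place of 4-chlorophenyl on a nitrogen on an aromatic ring), and that change gave a 2.7-fold higher number from compound 1 to compound 2 (0.44 log units; beyond the scatter).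

Compound 3 gives 34400 nM, a number within the scatter of both compound 1 and compound 2. The difference between the core of compound 3 and the core of compound 1 is not broken down here.

Compound 4 `CCOC(=O)CN(Cc1ccccc1)c1nc(Nc2cccc(OC)c2)ncc1[N+](=O)[O-]` has not yet been measured. It stands to compound 3 as compound 2 stands to compound 1, with 3-methoxyphenyl in place of 4-chlorophenyl on a nitrogen on an aromatic ring, and the place of the change reads the same in both pairs, so this is the same change made on a different core. Because the earlier instance gave a 2.7-fold higher number from compound 1 to compound 2 (0.44 log units; beyond the scatter), the step from compound 3 to compound 4 is expected to be a 2.5-fold higher number from compound 3 to compound 4 (0.39 log units; beyond the scatter), resting on that single prior occurrence and so held loosely. Compound 4 is therefore estimated at 85000 nM, with a range from 40000 nM to 180000 nM.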

Compound 4, half-maximal inhibitory concentration: 47200 nM
For compound 4 the middle estimate is 1.8-fold (0.26 log units) above the measured one; measured number inside the range.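

Carried to the second core, the swap to 3-methoxyphenyl from 4-chlorophenyl gave a 1.4-fold higher number from compound 3 to compound 4 (0.14 log units; within the scatter) in this assay. Set beside the earlier instance, the change does not differ measurably between the two cores: the same change on two cores in this assay, a 2.7-fold higher number (0.44 log units; beyond the scatter) from compound 1 to compound 2 and a 1.4-fold higher number (0.14 log units; within the scatter) from compound 3 to compound 4, 2.0-fold (0.30 log units) apart, within the scatter of two such steps

These two pairs are compatible with the change acting alike on both cores, but they do not establish that it does, since the second step taken alone cannot be told apart from the scatter and the first rests on a single pair, and they say nothing about how the change would behave on any other core.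

From the compounds shown here alone, all four compounds keep an ester on the chain, so what a carboxylic acid or an amide in its place would do in this assay remains open. Also open, going by these compounds, is how a plain phenyl or a pyridyl would compare with the two aryl groups on that same nitrogen, on either core.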